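From fluoro to trifluoromethyl when only limits are known

This account rests on a few compounds, and the source may have more. Where it says the series, first, only, none or still open, it means among the compounds named here.

In a functional assay on NCI-H1650 cells (Homo sapiens) for cytotoxicity, read by MTT assay, with a stated time of 72 h (a lower number here means a stronger inhibitor, a higher number a weaker inhibitor), compound 1 `CCOC(=O)C(COC(=O)/C=C/c1ccc(OC)c(OC)c1)c1ccc(F)cc1` gives > 0.01 ug/mL as its result, and this is a limit rather than a number. Compound 2 `CCOC(=O)C(COC(=O)c1ccccc1)c1ccc(C(F)(F)F)cc1` gives > 0.01 ug/mL as a limit too. Compound 3 `CCOC(=O)C(COC(=O)c1ccccc1OC(C)=O)c1ccc(C(F)(F)F)cc1` gives > 0.01 ug/mL as a limit as well. The shared mark is the limit of > 0.01 ug/mL in this assay, at which 3 of the 3 values shown sit, and no order among the three can be read from it. Compound 1 therefore has no exact place on the scale, only a limit that it shares with the other two.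

Compound 4 `CCOC(=O)C(COC(=O)/C=C/c1ccc(OC)c(OC)c1)c1ccc(C(F)(F)F)cc1` keeps the core of compound 1 and differs in one place: trifluoromethyl in place of fluoro on an aromatic carbon and the change reads as 4-fluorophenyl to 4-(trifluoromethyl)phenyl. Among the compounds with values here, the only measured step in this small set is a step that the two limits leave unreadable from compound 2 to compound 3 and it concerns acetoxy in place of hydrogen on an aromatic carbon, which is a different change. Within the data shown here, no measured pair tests trifluoromethyl in place of fluoro, so neither a size nor a direction can be drawn from the data. No step beyond the usual scatter is therefore expected in this assay for this change. The estimated step is a step that the limit leaves unreadable from compound 1 to compound 4 and it remains only an expectation. Compound 4 is expected at about 0.03 ug/mL within an estimated range of 0.01 ug/mL to 0.2 ug/mL. Its result may well also turn out to be only a limit.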

Compound 4, half-maximal inhibitory concentration: > 0.01 ug/mL
Compound 4: only a limit was reported (the forecaster's own chance of this, stated with the estimate: 80%); the middle value lies beyond the limit too.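

Compound 4 gives only a limit, as compound 1 does, so no step can be read from compound 1 to compound 4, and the change from fluoro to trifluoromethyl has neither size nor direction: the limit of > 0.01 ug/mL in this assay, at which 4 of the 4 values shown sit.

The compounds shown leave open where any of the four truly sits on the scale in this assay, and so how they rank.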